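The compounds below may be only part of what the source reports. "The series", "measured", "known", "first", "only" and "open" are said of these compounds alone.

Compound 1 `O=c1n(Cc2nc3ccc(C(F)(F)F)cn3c2CCCCO)c2cnccc2n1C1CC1`: in an ADME assay on HEp-2 cells (Homo sapiens) for cytotoxicity, read by CCK-8 assay, with a stated time of 6 days (on this read-out lower numbers stand for higher toxicity in this test and higher numbers for lower toxicity in this test), compound 1 gives > 100000 nM, a limit of the assay.
Compound 2 `CCc1ccn2c(CCCCO)c(Cn3c(=O)n(C4CC4)c4ccncc43)nc2c1`: compound 2 gives > 100000 nM, also a limit of the assay.
Compound 3 `N#Cc1c(Cn2c(=O)n(C3CC3)c3ccncc32)nc2cc(Cl)ccn12`: compound 3 gives 22500 nM.

Among the three, compound 3 is the only one that returns a number in this assay; the other two sit at the limit, as the limit of > 100000 nM in this assay, at which 2 of the 3 values shown sit, shows. Compound 4 `O=c1n(Cc2nc3cc(Cl)ccn3c2NC2CCCCC2)c2cnccc2n1C1CC1` differs from compound 3 in one place: cyclohexylamino in place of cyano on an aromatic carbon. Going by the values given here, no measured step covers such a change, so the expectation rests on compound 3 alone. For compound 4 a step of a 1.5-fold lower number from compound 3 to compound 4 (0.18 log units; within the scatter) is expected, toward somewhat higher toxicity, close to the edge of the usual scatter. Compound 4 is therefore estimated at 15000 nM, within a range of 5000 nM to 50000 nM.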

Compound 4, half-maximal cytotoxic concentration: > 100000 nM
Compound 4 was reported as a limit (the forecaster's own chance of this, stated with the estimate: 15%); at least 6.6-fold (0.82 log units) between middle value and limit.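

In this assay, cyclohexylamino in place of cyano on this aromatic carbon gives an at least 4.4-fold higher number from compound 3 to compound 4 (0.64 log units; beyond the scatter), which shows that a change at this position alone can move the read-out toward lower toxicity in this test. Compound 4 gives > 100000 nM, a limit of the assay. This leaves the full size of the step unresolved, and the limit is now a common result among these compounds: the limit of > 100000 nM in this assay, at which 3 of the 4 values shown sit.

On these data alone, whether a plain amino group, a smaller methylamino group or a carboxylic acid on this aromatic carbon would return a number or a limit remains open.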